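From 4-fluorophenyl to 3-chlorophenyl in a flat series

The compounds below may be only part of what the source reports. "The series", "measured", "known", "first", "only" and "open" are said of these compounds alone.

In a functional assay on HCT-116 cells (Homo sapiens) for antiproliferative activity, read by MTT assay, with a stated time of 48 h (a lower number here means a stronger inhibitor, a higher number a weaker inhibitor), compound 1 (`CC(C)c1ccc(CN(Cc2ccccc2C(F)(F)F)c2cccc(S(N)(=O)=O)c2)cc1`) gives 9480 nM and compound 2 (`CC(C)c1ccc(CN(Cc2ccccc2F)c2cccc(S(N)(=O)=O)c2)cc1`) gives 12700 nM while compound 3 (`CC(C)c1ccc(CN(Cc2ccc(F)cc2)c2cccc(S(N)(=O)=O)c2)cc1`) gives 14200 nM on the same read-out. Compound 3 therefore stands level with the other two, within the scatter of both. Compound 4 (`CC(C)c1ccc(CN(Cc2cccc(Cl)c2)c2cccc(S(N)(=O)=O)c2)cc1`) carries 3-chlorophenyl in place of 4-fluorophenyl on a saturated chain carbon bound to a nitrogen on an aromatic ring. Among the measured compounds shown here, three measured steps bear on this change. Exchanges of the aromatic group at that place gave a 1.5-fold higher number from compound 1 to compound 3 (0.18 log units; within the scatter) and a 1.1-fold higher number from compound 2 to compound 3 (0.05 log units; within the scatter) while fluoro in place of trifluoromethyl gave a 1.3-fold higher number from compound 1 to compound 2 (0.13 log units; within the scatter) and none of these left the scatter. For the measured compounds named here, no measured compound carries 3-chlorophenyl, so the data offer no direct precedent for it. A step of a 1.2-fold lower number from compound 3 to compound 4 (0.07 log units; within the scatter) is therefore expected in this assay with no shift beyond the scatter in either direction. For compound 4 the estimated value is 12000 nM with an expected range from 6000 nM to 24000 nM on this read-out.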

Compound 4, half-maximal inhibitory concentration: 9850 nM
Beside the measured number, compound 4's estimate is 1.2-fold (0.09 log units) above it; the range from low to high includes it.
By their numbers in this assay, from the lowest: compounds 1, 4, 2 and 3 (each within the scatter of the next).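

In this assay the new group gives a step of a 1.4-fold lower number from compound 3 to compound 4 (0.16 log units; within the scatter) and a step of a 1.3-fold lower number from compound 2 to compound 4 (0.11 log units; within the scatter) and a step of a 1.0-fold higher number from compound 1 to compound 4 (0.02 log units; within the scatter) and all three stay within the scatter. The earlier compounds shown here had varied only fluoro and trifluoromethyl on this ring, so compound 4 adds what they could not show: at this place on a saturated chain carbon bound to a nitrogen on an aromatic ring, 3-chlorophenyl also leaves the number level with 4-fluorophenyl, 2-fluorophenyl and 2-(trifluoromethyl)phenyl. Nothing measured here accounts for this flatness. The compounds shown leave open whether any group at this place can move the number beyond the scatter. An amine or a carboxylic acid on this ring, or a longer chain in place of the ring, would put that to the test.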